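Replacing an acetoxy group with a methoxycarbonylamino group

The source may report more compounds than this note shows. Statements on the series, on what has been measured and on what is new or still open speak of the compounds shown alone.

Three compounds sharing one core were tested in an ADME assay on L02 cells (Homo sapiens) for cytotoxicity, read by MTT assay, with a stated time of 48 h; on this read-out higher numbers stand for weaker inhibition and lower numbers for stronger inhibition. Compound 1 `CCN1CCN(C[C@H]2CN(c3ccc(-n4cc(-c5ccccn5)cn4)c(F)c3)C(=O)O2)CC1` gives 99 ug/mL. Compound 2 `O=C1O[C@@H](CN2CCC(c3ccc(F)cc3)CC2)CN1c1ccc(-n2cc(-c3ccccn3)cn2)c(F)c1` reaches only the assay limit, > 400 ug/mL. Compound 3 `CC(=O)OC[C@H]1CN(c2ccc(-n3cc(-c4ccccn4)cn3)c(F)c2)C(=O)O1` also reaches only the assay limit, > 400 ug/mL. Among the measured compounds shown here, the single measured step, an at least 4.0-fold higher number from compound 1 to compound 3 (0.60 log units; beyond the scatter), shows weaker cytotoxicity once acetoxy replaces 4-ethylpiperazin-1-yl. Compound 4 `COC(=O)NC[C@H]1CN(c2ccc(-n3cc(-c4ccccn4)cn3)c(F)c2)C(=O)O1` differs from compound 3 by (methoxycarbonyl)amino in place of acetoxy on a saturated chain carbon bound to a saturated ring carbon. For the measured compounds named here, no measured step covers this exchange; the step from compound 1 to compound 3 concerns other groups. Because two of the three values sit at the limit of > 400 ug/mL in this assay, at which 2 of the 3 values shown sit, compound 4 is expected to show no step beyond the scatter, a number no higher from compound 3 to compound 4 (the limit leaves the size open). Compound 4 is therefore estimated at 400 ug/mL, within 200 ug/mL to 800 ug/mL.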

Compound 4, half-maximal inhibitory concentration: 71 ug/mL
Compound 4: middle estimate off by 5.6-fold (0.75 log units), on the high side, and the stated range ends above it.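

In this assay, the group on a saturated chain carbon bound to a saturated ring carbon matters even among small chains: (methoxycarbonyl)amino in place of acetoxy gives an at least 5.6-fold lower number from compound 3 to compound 4 (0.75 log units; beyond the scatter). The other exchange gives a 1.4-fold lower number from compound 1 to compound 4 (0.14 log units; within the scatter), so 4-ethylpiperazin-1-yl is not needed for cytotoxicity of this level. The true size of the first step stays open, because compound 3 stands only at a limit: the limit of > 400 ug/mL in this assay, at which 2 of the 4 values shown sit.

Which part of (methoxycarbonyl)amino accounts for the step also stays open. An acetylamino group or a free primary amine at this place could help separate those parts.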